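Fluoro in Place of Cyano: One Step Estimated

A few compounds are considered here, and "the series" means these few. Any claim that something is new, unique, unknown or untested is made for them only; others in the source may bear on it.

Two compounds on one shared core open this account: compound 1 `CC1=C(c2ccc(C#N)cc2)C(c2ccc(OC[C@H](C)N3CC[C@@H](C)C3)cc2)Oc2ccc(O)cc21` and compound 2 `CC1=C(c2cccc(C#N)c2)C(c2ccc(OC[C@H](C)N3CC[C@@H](C)C3)cc2)Oc2ccc(O)cc21` in the same series. Within the data shown here, in an ADME assay on the whole organism for pharmacokinetics, with Mus musculus as the target, at a dose of 10 mg/kg by the oral route (on this read-out higher numbers stand for higher exposure at the dose given and lower numbers for lower exposure), compound 1 gives 2000 ng.h/mL as the only number available. Among the measured compounds shown here, for compound 2 the entry reads "not determined" (no result reported) and so compound 2 has no place on the scale, and no measured step starts from it.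

Compound 3 `CC1=C(c2cccc(F)c2)C(c2ccc(OC[C@H](C)N3CC[C@@H](C)C3)cc2)Oc2ccc(O)cc21` keeps the rest of compound 2 and carries fluoro in place of cyano on an aromatic carbon, meta to a large group. The 3-cyanophenyl thus becomes 3-fluorophenyl fluoro in place of cyano on an aromatic carbon in the structure. For the measured compounds named here, no measured pair shows what such a change does to the read-out, so the data argue for no direction. Going by the values given here, the step expected in this assay is therefore none beyond the scatter, and the only anchor is compound 1 at 2000 ng.h/mL with all the uncertainty that a single reference carries. Compound 3 is expected to come in near 1800 ng.h/mL with an estimated range from 600 ng.h/mL to 5000 ng.h/mL on this read-out.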

Compound 3, area under the concentration-time curve: 350 ng.h/mL
For compound 3 the middle estimate is 5.1-fold (0.71 log units) above the measured one; measured number below the stated range.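

In this assay the aryl group on the double-bonded ring carbon now has its first measured comparison, and that comparison shows a 5.7-fold lower number from compound 1 to compound 3 (0.76 log units; beyond the scatter), so exposure at this dose does respond to a change at this part of the shared core. The step replaces 4-cyanophenyl with 3-fluorophenyl, which alters both the group and where it stands on the ring, and this single pair cannot separate those two changes. Nothing measured here bears on why exposure falls across this step.

The step from 3-cyanophenyl to 3-fluorophenyl on its own cannot be read, since compound 2 has no number, so fluoro in place of cyano at one fixed place remains unresolved. The compounds shown also leave open how this read-out would respond to 4-fluorophenyl, to an unsubstituted phenyl, or to a phenyl ring carrying a methoxy group, an amine or a carboxylic acid.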